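Amide variation on the quinone-isoxazole-thiophene series

This account rests on a few compounds, and the source may have more. Where it says the series, first, only, none or still open, it means among the compounds named here.

Compound 3 `O=C1C=CC(=O)C(c2cc(-c3ccc(C(=O)N4CCC(C(F)(F)F)CC4)s3)on2)=C1` carries a 4-(trifluoromethyl)piperidin-1-yl amide; in a functional assay on PC-3 cells (Homo sapiens) for cytotoxicity, read by XTT assay, with a stated time of 72 h (a higher number here means a weaker inhibitor, a lower number a stronger inhibitor), compound 3 returns only a limit, > 30000 nM. Compound 1 `CN(C)C(=O)c1ccc(-c2cc(C3=CC(=O)C=CC3=O)no2)s1`, the dimethylamino analogue, gives 7200 nM in this assay. Within the data shown here, the step of an at least 4.1-fold higher number from compound 1 to compound 3 (0.61 log units; beyond the scatter) is the one measured change on the carbonyl carbon. Compound 2 `COc1ccc(OC)c(-c2cc(-c3ccc(C(=O)N4CCCC4)s3)on2)c1`, which carries a dimethoxyphenyl group in place of the quinone and a pyrrolidinyl amide, also stops at a limit, > 30000 nM. Compound 3 thus stands at the weak end of what has been measured, sharing with compound 2 the position described by the limit of > 30000 nM in this assay, at which 2 of the 3 values shown sit.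

Compound 4 `CN(Cc1ccccc1)C(=O)c1ccc(-c2cc(C3=CC(=O)C=CC3=O)no2)s1` is the next variant on the carbonyl carbon: benzyl(methyl)amino in place of 4-(trifluoromethyl)piperidin-1-yl on a carbonyl carbon. Among the measured compounds shown here, only the step from compound 1 to compound 3 bears on this, and it ran toward weaker inhibition when the dimethylamino group was exchanged for the larger ring. The benzyl(methyl)amino group is likewise larger than dimethylamino, so compound 4 is expected to fall between compound 1 and compound 3 rather than recover the value of compound 1. The step of an at least 1.5-fold lower number from compound 3 to compound 4 (0.17 log units; that floor lies within the scatter) is expected to be small and may not leave the limit. Compound 4 is estimated at 20000 nM, with a range from 6000 nM to 60000 nM.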

Compound 4, half-maximal inhibitory concentration: 11000 nM
For compound 4 the middle estimate is 1.8-fold (0.26 log units) above the measured one; low and high end bracket the measured number.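

The enlarged amide does not by itself carry the series to the limit: in this assay the exchange of 4-(trifluoromethyl)piperidin-1-yl for benzyl(methyl)amino on the carbonyl carbon gives an at least 2.7-fold lower number from compound 3 to compound 4 (0.43 log units; beyond the scatter) and so yields a measurable value. Phenyl in place of hydrogen on the saturated chain carbon bound to the amide-type nitrogen gives a 1.5-fold higher number from compound 1 to compound 4 (0.18 log units; within the scatter) and leaves this pair without an order. Compound 4 therefore goes against reading the earlier step to compound 3 as a general loss on enlarging the amide, and readings at the limit stay confined to compound 2 and compound 3: the limit of > 30000 nM in this assay, at which 2 of the 4 values shown sit.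

Still open, as far as these compounds go, is how an amide built on a piperazine, or one bearing a carboxylic acid on its amine part, would read at this carbonyl carbon, and whether a methoxy group on the phenyl ring of benzyl(methyl)amino would shift the value. The dimethoxyphenyl group and the pyrrolidinyl amide change together in compound 2, and no compound shown separates the two.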